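A few compounds are considered here, and "the series" means these few. Any claim that something is new, unique, unknown or untested is made for them only; others in the source may bear on it.

Measured compounds:
compound 1 `COc1ccc(F)cc1CNCCCNc1ccnc2cc(C3CCCCC3)ccc12`, 23 10^-6 cm/s
compound 2 `COc1cccc(CNCCCNc2ccnc3cc(Oc4cccc(N(C)C)c4)ccc23)c1O`, 317 10^-6 cm/s
compound 3 `c1coc(CNCCCNc2ccnc3cc(C4CCCCC4)ccc23)c1`, 23 10^-6 cm/s

These three were tested in an ADME assay for permeability, using PAMPA, with a stated time of 30 min, at pH 7.4; on this read-out lower numbers stand for lower permeability and higher numbers for higher permeability. Compound 1 gives 23 10^-6 cm/s and stands level with compound 3, the two together being the lowest of the three numbers; compound 2 gives a far higher value. For the measured compounds named here, the one step that can be read directly, no change at the digits printed from compound 1 to compound 3 (within the scatter), shows that swapping the group on the chain carbon bound to the amine nitrogen leaves this assay untouched. The new compound 4 `COc1ccc(F)cc1CNCCCNc1ccnc2cc(Oc3ccccc3OC)ccc12` changes a different part of compound 1: 2-methoxyphenoxy in place of cyclohexyl on an aromatic carbon. Going by the values given here, no measured pair isolates that change. Compound 2, which carries an aryloxy group at the same kind of aromatic carbon, differs from compound 1 in several places at once, so its much higher number is only a loose hint. A moderate rise, a 2.6-fold higher number from compound 1 to compound 4 (0.42 log units; beyond the scatter), is therefore expected, though with wide uncertainty. Compound 4 is estimated at 60 10^-6 cm/s, between 20 10^-6 cm/s and 200 10^-6 cm/s.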

Compound 4, apparent permeability: 317 10^-6 cm/s
For compound 4 the middle estimate is 5.3-fold (0.72 log units) below the measured one; measured number above the stated range.
By their numbers in this assay, from the lowest: compounds 1 and 3 (each within the scatter of the next); then compounds 2 and 4 (each within the scatter of the next).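

In this assay, for the compounds shown here, putting 2-methoxyphenoxy in place of cyclohexyl on this aromatic carbon gives a 14-fold higher number from compound 1 to compound 4 (1.14 log units; beyond the scatter) and is the first single change here to move the number beyond the scatter. The earlier single change, on the chain carbon bound to the amine nitrogen, gave no change at the digits printed from compound 1 to compound 3 (within the scatter) and so left the number in place. Nothing measured here explains the rise.
From the compounds shown here alone, it remains open whether plain phenoxy or a phenyl ring bound directly to this carbon would give a similar number. The same question stands for the 2-methoxyphenoxy group paired with furan-2-yl on the chain.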